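Methyl for cyclopropylsulfonyl on the sulfonamide aryl ring

This account rests on a few compounds, and the source may have more. Where it says the series, first, only, none or still open, it means among the compounds named here.

Measured compounds:
compound 1 `Cc1c(C(=O)NCCCN2CCN(C)CC2)c(-c2cccc(N3CCN(c4ccc(NS(=O)(=O)c5cccc(S(=O)(=O)C6CC6)c5)cc4)CC3)c2)c(-c2ccc(Cl)cc2)n1C` with 218 nM
compound 2 `CCn1c(C)c(C(=O)O)c(-c2cccc(N3CCN(c4ccc(NS(=O)(=O)c5ccc(N[C@H](CCN6CCC(O)CC6)CSc6ccccc6)c(S(=O)(=O)C(F)(F)F)c5)cc4)CC3)c2)c1-c1ccc(Cl)cc1` with 1.2 nM
compound 3 `Cc1c(C(=O)O)c(-c2cccc(N3CCN(c4ccc(NS(=O)(=O)c5ccc(N[C@H](CCN6CCCC6)CSc6ccccc6)c(S(=O)(=O)C(F)(F)F)c5)cc4)CC3)c2)c(-c2ccc(Cl)cc2)n1C` with 1.8 nM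

In an assay for binding affinity to Apoptosis regulator Bcl-2 (Homo sapiens), read by fluorescence polarization, with a stated time of 2 h (on this read-out higher numbers stand for weaker inhibition and lower numbers for stronger inhibition), compound 1 gives 218 nM, the highest of the three numbers. For the measured compounds named here, compound 2 gives 1.2 nM and compound 3 gives 1.8 nM; both lie far from compound 1, beyond the scatter, but each differs from compound 1 in more than one place, so no single step between measured compounds is available.

Compound 4 `Cc1cccc(S(=O)(=O)Nc2ccc(N3CCN(c4cccc(-c5c(C(=O)NCCCN6CCN(C)CC6)c(C)n(C)c5-c5ccc(Cl)cc5)c4)CC3)cc2)c1` differs from compound 1 by methyl in place of cyclopropylsulfonyl on an aromatic carbon. The cyclopropylsulfonyl group, which carries both hydrogen-bond acceptors counted there, is lost and only a one-carbon group enters. Going by the values given here, nothing among the measured compounds tests this change directly.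

The step from compound 1 to compound 4 is expected to be a 2.8-fold higher number from compound 1 to compound 4 (0.44 log units; beyond the scatter), a modest move toward a higher number, possibly not beyond the scatter. For compound 4 the estimate in this assay is 600 nM, within 200 nM to 2500 nM.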

Compound 4, inhibition constant: 178 nM
The estimate for compound 4 lay 3.4-fold (0.53 log units) above the measured number; the measured number lies below the stated range.
By their numbers in this assay, from the lowest: compounds 2 and 3 (each within the scatter of the next); then compounds 4 and 1 (each within the scatter of the next).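

At this aromatic carbon, in this assay, methyl in place of cyclopropylsulfonyl gives a 1.2-fold lower number from compound 1 to compound 4 (0.09 log units; within the scatter), so this read-out does not separate the two groups on this core. The three-membered ring and both hydrogen-bond acceptors of the cyclopropylsulfonyl group can therefore be absent here without a step beyond the scatter, and a one-carbon group serves equally well in this pair. No measurement at hand offers a reason for this result.

On these data alone, whether a nitrile, a methoxy group or a plain hydrogen at this aromatic carbon would also stay within the scatter of compound 1 remains open. Also open, as far as these compounds go, is whether this change would read the same way with a carboxylic acid in place of the amide chain, since compound 2 and compound 3 differ from compound 1 in more than one place.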